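The source may hold more compounds than are shown below. What is called first, only, known or untested is meant among the compounds shown, and "the series" means these compounds.

Measured in a functional assay, read by spectrophotometry, with a stated time of 6 min; a higher number here means that more compound is needed for the effect, a lower number that less compound is needed:
- compound 1 `COc1c(C)cc(O)cc1C/C=C(\C)CC(=O)/C=C(/C)CCCC(C)C(=O)/C=C/C(C)(C)O`: 26300 nM
- compound 2 `COc1c(C)cc(O)cc1C/C=C(\C)CC(=O)/C=C(/C)CCCC(C)=O`: 51600 nM
- compound 3 `COc1c(C)cc(O)cc1C/C=C(\C)CC(=O)/C=C(\C)CCCC(C)=O`: 33300 nM

Compound 2 is not separated from its two neighbours, since a 2.0-fold higher number from compound 1 to compound 2 (0.29 log units; within the scatter) and a 1.5-fold lower number from compound 2 to compound 3 (0.19 log units; within the scatter). Compound 4 `COc1c(C)cc(O)cc1C/C=C(\C)CC(=O)/C=C(/C)CCCC(C)(O)C(=O)/C=C/C(C)(C)O` is derived from compound 2 by this change: 1-hydroxy-1-((3-hydroxy-3-methylbut-1-en-1-yl)carbonyl)ethyl in place of acetyl on a saturated chain carbon, three bonds along the chain from a double-bonded chain carbon. Within the data shown here, the only measured step that bears on it is the first of these, which removes a nearly identical side chain, lacking only the 1-hydroxy group. The second concerns only a double bond's configuration. In this assay, no change beyond the scatter is therefore expected, with compound 4 likely close to compound 1. The expected step is a 1.7-fold lower number from compound 2 to compound 4 (0.24 log units; within the scatter). For compound 4 the estimated value is 30000 nM, with an expected range of 13000 nM to 65000 nM.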

Compound 4, half-maximal effective concentration: 43100 nM
Beside the measured number, compound 4's estimate is 1.4-fold (0.16 log units) below it; measured number inside the range.
By their numbers in this assay, from the lowest: compounds 1, 3, 4 and 2 (each within the scatter of the next).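

In this assay, the 1-hydroxy-1-((3-hydroxy-3-methylbut-1-en-1-yl)carbonyl)ethyl group in place of acetyl on this saturated chain carbon stays within the scatter (a 1.2-fold lower number from compound 2 to compound 4 (0.08 log units; within the scatter)). Hydroxy in place of hydrogen on the same carbon also stays within it (a 1.6-fold higher number from compound 1 to compound 4 (0.21 log units; within the scatter)), so neither change separates the compounds at this position. Nothing available here accounts for this result.

Going by these compounds, whether an amine or a carboxylic acid on this carbon would give a step beyond the scatter remains open. All compounds shown keep the shared core, so the effect of changes there is also open.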